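Sulfonyl group swap from compound 3 to compound 4

The compounds below may be only part of what the source reports. "The series", "measured", "known", "first", "only" and "open" are said of these compounds alone.

In an ADME assay on HEK293 cells (Homo sapiens) for cytotoxicity, read by resazurin assay, with a stated time of 48 h (on this read-out lower numbers stand for higher toxicity in this test and higher numbers for lower toxicity in this test), compound 3 (`O=S(=O)(Nc1ccc(-c2nc3ccccc3o2)cc1)c1ccccc1F`) reads > 100000 nM as a limit of the assay and not a number. Compound 1 (`O=S(=O)(Nc1ccc(-c2nc3ccccc3o2)cc1)c1ccc(Cl)s1`) reads > 100000 nM as a limit too. Among the compounds with values here, compound 2 (`O=S(=O)(Nc1ccc(-c2nc3ccccc3o2)cc1)c1ccc(F)c(C(F)(F)F)c1`) gives 82000 nM as the only true number of the three. Compound 3 thus sits at the limit of > 100000 nM in this assay, at which 2 of the 3 values shown sit, with no exact place on the scale.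

Compound 4 (`CCc1ccc(S(=O)(=O)Nc2ccc(-c3nc4ccccc4o3)cc2)cc1`) carries 4-ethylphenyl in place of 2-fluorophenyl on a sulfonyl sulfur with the shared core unchanged.

Within the data shown here, only one measured step touches this place: a step that the two limits leave unreadable from compound 1 to compound 3 with 2-fluorophenyl in place of 5-chlorothiophen-2-yl. It offers no size to carry over. Compound 2 at 82000 nM is the nearest guide to a number, so no step beyond the scatter is expected in this assay from this change, and no direction can be claimed. The estimated move is an at least 1.1-fold lower number from compound 3 to compound 4 (0.04 log units; that floor lies within the scatter) and it is expected to stay small or unreadable. For compound 4 the estimated value is 90000 nM with an expected range from 40000 nM to 150000 nM in this assay and a report of only a limit remains the likelier outcome.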

Compound 4, half-maximal cytotoxic concentration: 82000 nM
The estimate for compound 4 lay 1.1-fold (0.04 log units) above the measured number; low and high end bracket the measured number.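

In this assay the place on the sulfonyl sulfur now gives readable steps (an at least 1.2-fold lower number from compound 3 to compound 4 (0.08 log units; that floor lies within the scatter); an at least 1.2-fold lower number from compound 1 to compound 4 (0.08 log units; that floor lies within the scatter)), whereas the earlier step between the 5-chlorothiophen-2-yl and 2-fluorophenyl compounds cannot be read. With 4-ethylphenyl at this place the read-out is an exact number and not a limit, and compound 4 prints the same number as compound 2 (82000 nM), so the series now holds two exact values at this position. Both new steps have only a floor, that floor lies within the scatter, and no change of any real size is established by them, as limits remain among the values: the limit of > 100000 nM in this assay, at which 2 of the 4 values shown sit.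

From the compounds shown here alone, how far compound 1 and compound 3 lie beyond their limits stays open, and with it the true size of both steps. Also open, going by these compounds, is whether an amine or a carboxylic acid on the phenyl ring at this place, or a longer chain in place of the ethyl group, would give a step beyond the scatter in this assay.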